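From Hex-1-yn-1-yl to 2-Phenylethenyl on a Shared Core

This account rests on a few compounds, and the source may have more. Where it says the series, first, only, none or still open, it means among the compounds named here.

Compound 1 `CCCCC#Cc1cc([C@@H]2O[C@H](CO)[C@@H](O)[C@H]2O)n2ncnc(N)c12`: 2900 nM
Compound 2 `Nc1ncnn2c([C@@H]3O[C@H](CO)[C@@H](O)[C@H]3O)cc(-c3ccccc3)c12`: 82600 nM
Compound 3 `Nc1ncnn2c([C@@H]3O[C@H](CO)[C@@H](O)[C@H]3O)cc(-c3ccccc3F)c12`: a limit of the assay, > 100000 nM

The three compounds were tested in a functional assay on HCT-116 cells (Homo sapiens) for antiproliferative activity, with a stated time of 72 h; a lower number here means a stronger inhibitor, a higher number a weaker inhibitor. Compound 1 gives 2900 nM, the lowest of the two numbers shown. Compound 2 gives 82600 nM. For compound 3 only a limit of the assay is known, > 100000 nM, which is the limit of > 100000 nM in this assay, at which 1 of the 3 values shown sits. Putting phenyl in place of the alkyne gives a 28-fold higher number from compound 1 to compound 2 (1.45 log units; beyond the scatter), and putting 2-fluorophenyl there gives an at least 34-fold higher number from compound 1 to compound 3 (1.53 log units; beyond the scatter). Between the two aryl compounds the change gives an at least 1.2-fold higher number from compound 2 to compound 3 (0.08 log units; that floor lies within the scatter).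

Compound 4 `Nc1ncnn2c([C@@H]3O[C@H](CO)[C@@H](O)[C@H]3O)cc(/C=C/c3ccccc3)c12` has not been measured. Compared with compound 1 it carries 2-phenylethenyl in place of hex-1-yn-1-yl on an aromatic carbon. The two measured steps that bear on it both exchange hex-1-yn-1-yl for an aromatic ring and both were large losses. The entering 2-phenylethenyl also holds one six-membered aromatic ring of carbon only, joined through a double bond rather than directly, so compound 4 is expected to be weaker than compound 1 because compound 2 showed a 28-fold higher number from compound 1 to compound 2 (1.45 log units; beyond the scatter), with an 8.6-fold higher number from compound 1 to compound 4 (0.94 log units; beyond the scatter). The estimate for compound 4 is 25000 nM, between 6000 nM and 100000 nM.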

Compound 4, half-maximal inhibitory concentration: 4800 nM
Compound 4: middle estimate off by 5.2-fold (0.72 log units), on the high side; measured number below the stated range.
By their numbers in this assay, from the lowest: compounds 1 and 4 (each within the scatter of the next); then compound 2. At a limit, above all of these: compound 3.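

Carrying an aromatic ring on this aromatic carbon does not by itself mean a large loss: 2-phenylethenyl in place of hex-1-yn-1-yl gives a 1.7-fold higher number from compound 1 to compound 4 (0.22 log units; within the scatter), so the two groups cannot be told apart here. How the ring is joined makes the difference, as a ring held through a double bond rather than directly gives a 17-fold lower number from compound 2 to compound 4 (1.24 log units; beyond the scatter), and against the 2-fluorophenyl group gives an at least 20-fold lower number from compound 3 to compound 4 (1.31 log units; beyond the scatter). That last step rests on a limit for compound 3: the limit of > 100000 nM in this assay, at which 1 of the 4 values shown sits.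

The compounds shown leave open whether the double bond itself is needed, a question that a 2-phenylethyl group, with a saturated link, or a 2-phenylethynyl group, with a triple bond, could address. They also leave open what a fluoro or an amine on the ring of the 2-phenylethenyl group would do.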